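This account rests on a few compounds, and the source may have more. Where it says the series, first, only, none or still open, it means among the compounds named here.

Compound 1 `c1ccc(-c2cnoc2)c(NCC2=NCCN2)c1`: in a functional assay for activation of Alpha-1D adrenergic receptor (Homo sapiens) (a lower number here means that less compound is needed, a higher number that more compound is needed for the effect), compound 1 gives < 100000 nM, which is a limit of the assay.
Compound 2 `Cc1ccc(-c2ccccc2NCC2=NCCN2)o1`: in this assay compound 2 gives < 2000 nM, likewise a limit of the assay.

Within the data shown here, compound 2 therefore stands only at a limit, and the one other value shown is a limit as well, namely the limit of < 100000 nM in this assay, at which 1 of the 2 values shown sits, beside (the limit of < 2000 nM in this assay, at which 1 of the 2 values shown sits). Among the measured compounds shown here, the single measured step, a step that the two limits leave unreadable from compound 1 to compound 2, cannot be read for size between the two limits. Compound 3 `c1cnc(-c2ccccc2NCC2=NCCN2)nc1` differs from compound 2 by pyrimidin-2-yl in place of 5-methylfuran-2-yl on an aromatic carbon. For the measured compounds named here, no measured step bears readably on this change, so the expectation for compound 3 rests on the limit of compound 2 alone, and the step from compound 2 to compound 3 is expected as a step that the limit leaves unreadable from compound 2 to compound 3, with no direction that the data support. Compound 3 is estimated in this assay at 1500 nM, with a range from 200 nM to 10000 nM.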

Compound 3, half-maximal effective concentration: 81.3 nM
Estimate against measurement, compound 3: 18-fold (1.27 log units) above, outside the stated range (below it).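

Neither the step from compound 1 to compound 3 nor the step from compound 2 to compound 3 can be read for size: the values of compound 1 and compound 2 are limits of the assay. The compounds shown leave open, in this assay, how pyrimidin-2-yl, 5-methylfuran-2-yl and 1,2-oxazol-4-yl rank against one another on the shared core.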